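Three Compounds at the Assay Limit, and a Fourth

The compounds below may be only part of what the source reports. "The series", "measured", "known", "first", "only" and "open" are said of these compounds alone.

Compound 1 `COc1cccc(/C=C/C(=O)c2ccc(OC)c3c2OC(C)(C)C=C3)c1` — > 10000 nM
Compound 2 `COc1ccc(C(=O)/C=C/c2ccc(Br)cc2)c2c1C=CC(C)(C)O2` — > 10000 nM
Compound 3 `COc1ccc(C(=O)/C=C/c2cccc(O)c2)c2c1C=CC(C)(C)O2` — > 10000 nM

In a functional assay on HT-29 cells (Homo sapiens) for antiproliferative activity, read by MTT assay, with a stated time of 24 h (a higher number here means a weaker inhibitor, a lower number a stronger inhibitor), compound 1 gives > 10000 nM, which is a limit of the assay and not a number. Compound 2 gives > 10000 nM in this assay, again a limit. Compound 3 likewise reaches only > 10000 nM in this assay. Compound 1 therefore stands nowhere in particular on the numbers shown: all three values sit at the limit of > 10000 nM in this assay, at which 3 of the 3 values shown sit, and no measured value separates any of them.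

The measured steps are accordingly unreadable. The step that the two limits leave unreadable from compound 1 to compound 2 and the step that the two limits leave unreadable from compound 1 to compound 3 are both hidden by the limits, as is a step that the two limits leave unreadable from compound 2 to compound 3.

Compound 4 `COc1ccc(C(=O)/C=C/c2ccc(O)c(Br)c2)c2c1C=CC(C)(C)O2` has not yet been measured. It differs from compound 1 as follows: 3-bromo-4-hydroxyphenyl in place of 3-methoxyphenyl on a double-bonded chain carbon bound to a double-bonded chain carbon. Within the data shown here, the steps that bear on it are the two from compound 1 to compounds 2 and 3, which bring in a bromine on the ring and a hydroxyl on the ring; neither gave a readable size. No direction or size of step can be drawn from them, and the most likely outcome is another limit. Compound 4 is therefore expected to give about 15000 nM, somewhere between 5000 nM and 60000 nM. The step that the limit leaves unreadable from compound 1 to compound 4 is thus expected to be essentially none beyond the scatter.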

Compound 4, half-maximal inhibitory concentration: > 10000 nM
Compound 4: a limit, no number; the forecaster's own chance of this, stated with the estimate: 80%; the middle value does not contradict the limit.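

In this assay compound 4 gives > 10000 nM as a limit of the assay and not a number. Among these compounds, no step from compound 1, compound 2 or compound 3 to compound 4 can be read, and all four compounds stand together: the limit of > 10000 nM in this assay, at which 4 of the 4 values shown sit. The compounds shown leave open whether any of these replacements on the shared core changes antiproliferative activity at all.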